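This account rests on a few compounds, and the source may have more. Where it says the series, first, only, none or still open, it means among the compounds named here.

Compound 1 `CO/N=C/c1c(N)ncnc1Oc1ccc2[nH]ccc2c1` is the parent of this small set. For the measured compounds named here, in a functional assay on HCT-116 cells (Homo sapiens) for antiproliferative activity (a lower number here means a stronger inhibitor, a higher number a weaker inhibitor), compound 1 gives 3520 nM, the highest of the three numbers measured so far. Compound 2 `CO/N=C/c1c(N)ncnc1Oc1ccc2[nH]cc(C)c2c1` gives 385 nM and compound 3 `CO/N=C/c1c(N)ncnc1Oc1cc2cc[nH]c2cc1F` gives 422 nM. Both steps away from the parent run in the same direction and are of similar size: a 9.1-fold lower number from compound 1 to compound 2 (0.96 log units; beyond the scatter), and an 8.3-fold lower number from compound 1 to compound 3 (0.92 log units; beyond the scatter).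

Compound 4 `CO/N=C/c1c(N)ncnc1Oc1ccc2c(ccn2C)c1` has not yet been measured. It differs from compound 1 by methyl in place of hydrogen on an aromatic nitrogen. Going by the values given here, the two measured steps each add a single small group to the fused ring system, so they are the closest comparisons available, but both sit on an aromatic carbon; no measured step touches the aromatic nitrogen, so they bear on the new step only by analogy. A further move in the same direction cannot be ruled out, yet nothing measured shows that the nitrogen behaves like the carbons. The step of a 2.0-fold lower number from compound 1 to compound 4 (0.29 log units; within the scatter) is therefore expected to be small, with wide uncertainty. For compound 4 the estimate in this assay is 1800 nM, with a range from 400 nM to 8000 nM.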

Compound 4, half-maximal inhibitory concentration: 749 nM
Compound 4: middle estimate off by 2.4-fold (0.38 log units), on the high side; measured number inside the range.
By their numbers in this assay, from the lowest: compounds 2, 3 and 4 (each within the scatter of the next); then compound 1.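

In this assay, the aromatic nitrogen of the five-membered aromatic ring accepts a substituent without loss against the parent: a 4.7-fold lower number from compound 1 to compound 4 (0.67 log units; beyond the scatter). The earlier steps showed a lower number only for changes on an aromatic carbon; this one shows that replacing the hydrogen on the aromatic nitrogen with methyl runs the same way, so all three single changes to compound 1 lower the number, and no compound shown goes against this. No measurement shown bears on why this step has the size it has.

Going by these compounds, whether an ethyl group, a longer chain or a chain ending in an amine on this nitrogen keeps the same direction remains open. Also open, on these data alone, is whether methyl on the aromatic nitrogen combines with methyl or fluoro on an aromatic carbon in a single compound.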